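Solubility notes: aryl substituent on the pyrrole nitrogen

The source may report more compounds than this note shows. Statements on the series, on what has been measured and on what is new or still open speak of the compounds shown alone.

Measured compounds in a physicochemical assay for solubility, read by nephelometry, in phosphate buffer, measured as kinetic solubility, at pH 6.5; on this read-out lower numbers stand for lower solubility and higher numbers for higher solubility:
compound 1 `CCOC(=O)C1=C(C)N/C(=C/c2cc(C)n(-c3ccc(F)cc3F)c2C)C1=O` gives 6.3 ug/mL
compound 2 `CCOC(=O)C1=C(C)N/C(=C/c2cc(C)n(-c3ccc(Br)cc3)c2C)C1=O` gives 2.1 ug/mL
compound 3 `CCOC(=O)C1=C(C)N/C(=C/c2cc(C)n(-c3ccncc3)c2C)C1=O` gives 50 ug/mL

Compound 2 stands lowest of the three: a 3.0-fold lower number from compound 1 to compound 2 (0.48 log units; beyond the scatter), and a 24-fold higher number from compound 2 to compound 3 (1.38 log units; beyond the scatter). Compound 4 `CCOC(=O)C1=C(C)N/C(=C/c2cc(C)n(-c3ccc(CN4CCCCC4)cc3)c2C)C1=O` is not yet measured; it differs from compound 2 by (piperidin-1-yl)methyl in place of bromo on an aromatic carbon. Within the data shown here, no measured step covers this change. Among the measured compounds shown here, the only steps at hand exchange the whole aryl group on the pyrrole nitrogen, and the swap to a nitrogen-containing ring was large: a 24-fold higher number from compound 2 to compound 3 (1.38 log units; beyond the scatter), with a 7.9-fold higher number from compound 1 to compound 3 (0.90 log units; beyond the scatter) pointing the same way. An upward step beyond the scatter is therefore expected in this assay, estimated as a 29-fold higher number from compound 2 to compound 4 (1.46 log units; beyond the scatter). Compound 4 is expected to give about 60 ug/mL, within 15 ug/mL to 250 ug/mL.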

Compound 4, solubility: 12.5 ug/mL
Compound 4: the middle estimate sits 4.8-fold (0.68 log units) above what was measured; measured number below the stated range.
By their numbers in this assay, from the lowest: compound 2; then compounds 1 and 4 (each within the scatter of the next); then compound 3.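

In this assay, (piperidin-1-yl)methyl in place of bromo gives a 6.0-fold higher number from compound 2 to compound 4 (0.77 log units; beyond the scatter). The earlier steps shown here exchanged the whole aryl group on the pyrrole nitrogen, whereas this one keeps the six-membered aromatic ring of carbon only and changes a single substituent on it, and the number still moves beyond the scatter. Nothing measured here accounts for the size of this step.

Still open, from the compounds shown here alone, is how morpholin-4-ylmethyl or dimethylaminomethyl at this place would compare with (piperidin-1-yl)methyl. Going by these compounds, a carboxylic acid at this place is equally open.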